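The source may hold more compounds than are shown below. What is called first, only, known or untested is meant among the compounds shown, and "the series" means these compounds.

For the measured compounds named here, compound 1 `O=C1[C@@H](NS(=O)(=O)c2ccc(-c3ccon3)s2)CCN1Cc1cc2c[nH]ccc-2n1` gives 17% in an assay on isolated protein for inhibition of coagulation factor X (Oryctolagus cuniculus), tested at 1 uM (on this read-out lower numbers stand for less inhibition and higher numbers for more inhibition at the one concentration tested (going by the name of the read-out)), the lowest of the three numbers so far. Compound 3 `O=C1[C@@H](NS(=O)(=O)c2ccc(-c3ccncc3)s2)CCN1Cc1cc2c[nH]ccc-2n1` gives 21%, a difference within the scatter, while compound 2 `O=C1[C@@H](NS(=O)(=O)c2cc3c(Cl)nccc3s2)CCN1Cc1cc2c[nH]ccc-2n1` gives 35%, a step of a number 18 percentage points higher from compound 1 to compound 2 (beyond the scatter). Compound 4 `O=C1[C@@H](NS(=O)(=O)c2ccc(-c3ccon3)s2)CCN1CCNc1ccncc1` differs from compound 1 at another place: a group of 8 heavy atoms (6 carbon, 2 nitrogen; one six-membered aromatic ring with 1 hetero atom) in place of a group of 9 heavy atoms (7 carbon, 2 nitrogen; one five-membered aromatic ring with 1 hetero atom, one six-membered aromatic ring with 1 hetero atom), on a saturated chain carbon bound to an amide-type nitrogen in a ring. Both measured steps, a number 18 percentage points higher from compound 1 to compound 2 (beyond the scatter) and a number 4 percentage points higher from compound 1 to compound 3 (within the scatter), change the group on the sulfonyl sulfur and leave this place untouched, so neither bears directly on the new change. Going by the values given here, with no guiding step, only a small shift is expected, a number 4 percentage points lower from compound 1 to compound 4 (within the scatter). Compound 4 is therefore estimated at 13%, within a range of 0% to 35%.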

Compound 4, a percentage reported as inhibition, at one concentration (the size of the read-out at that concentration, not a potency): 22%
Estimate against measurement, compound 4: 9 percentage points below; low and high end bracket the measured number.
By their numbers in this assay, from the lowest: compounds 1, 3 and 4 (each within the scatter of the next); then compound 2.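

For the compounds shown here, replacing the group on a saturated chain carbon bound to an amide-type nitrogen in a ring with ((pyridin-4-yl)amino)methyl gives a number 5 percentage points higher from compound 1 to compound 4 (within the scatter) in this assay and is the first view of this place. The read-out thus does not separate the two groups, although the entering group has one ring where the leaving group has two. Nothing available explains this result. From the compounds shown here alone, whether a plain amine or a carboxylic acid at this place would shift the number remains open. So does whether this change would give the same result with the sulfonyl group of compound 2.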